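Swapping the Aryl Group on the Double-Bonded Nitrogen of Compound 2

The source may hold more compounds than are shown below. What is called first, only, known or untested is meant among the compounds shown, and "the series" means these compounds.

Compound 2 `O=C1Nc2ccc(S(=O)(=O)N3CCOCC3)cc2/C1=N/c1ccc(Br)cc1` gives 11900 nM in a functional assay on HepG2 cells (Homo sapiens) for cytotoxicity, read by sulforhodamine B assay, with a stated time of 24 h; on this read-out lower numbers stand for stronger inhibition and higher numbers for weaker inhibition. Among the three compounds with numbers it stands second highest; compound 3 `Cc1ccc(/N=C2\C(=O)Nc3ccc(S(=O)(=O)N4CCOCC4)cc32)cc1` gives 12800 nM and compound 1 `N=c1oc2ccccc2cc1C(=O)N/N=C1\C(=O)Nc2ccc(S(=O)(=O)N3CCOCC3)cc21` gives 7820 nM, and both lie within the scatter of compound 2. Compound 4 `O=C1Nc2ccc(S(=O)(=O)N3CCOCC3)cc2/C1=N/c1cccc(C(F)(F)F)c1` differs from compound 2 in one place: 3-(trifluoromethyl)phenyl in place of 4-bromophenyl on a double-bonded nitrogen. Going by the values given here, the only measured step that bears on a change of the group on the double-bonded nitrogen is a 1.1-fold higher number from compound 2 to compound 3 (0.03 log units; within the scatter), which stayed within the scatter. Among the compounds with values here, no measured step involves the 3-(trifluoromethyl)phenyl group itself. Compound 4 is therefore expected to show no step beyond the scatter, a 1.0-fold higher number from compound 2 to compound 4 (0.00 log units; within the scatter). The estimate for compound 4 is 12000 nM, with a range from 5000 nM to 30000 nM.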

Compound 4, half-maximal inhibitory concentration: 14300 nM
Estimate against measurement, compound 4: 1.2-fold (0.08 log units) below; the measured number falls inside the stated range.
By their numbers in this assay, from the lowest: compounds 1, 2, 3 and 4 (each within the scatter of the next).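

Replacing 4-bromophenyl with 3-(trifluoromethyl)phenyl on the double-bonded nitrogen gives a 1.2-fold higher number from compound 2 to compound 4 (0.08 log units; within the scatter) in this assay, and replacing 4-methylphenyl with the same group gives a 1.1-fold higher number from compound 3 to compound 4 (0.05 log units; within the scatter). This place therefore now holds three substituted phenyl groups that cannot be told apart in this read-out, one of them named with its substituent at 3 rather than 4. Nothing given here accounts for this result.

The compounds shown leave open whether a phenyl bearing an amine or a carboxylic acid would move the number beyond the scatter. They also leave open what a pyridine ring or a plain alkyl chain would do at this place.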